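The compounds below may be only part of what the source reports. "The series", "measured", "known", "first", "only" and "open" are said of these compounds alone.

Going by the values given here, compound 1 `CCCCNc1nc(N)nc(C)c1CCCN1CCN(C)CC1` gives 179 nM in an assay on HEK293 cells for agonist activity at Toll-like receptor 8 (Homo sapiens), read by spectrophotometry (on this read-out lower numbers stand for an effect already at smaller amounts and higher numbers for an effect only at larger amounts of compound), the lowest of the two numbers so far; compound 2 `CCCCNc1nc(N)nc(C)c1CCCn1cncn1` gives 1050 nM, and a 5.9-fold higher number from compound 1 to compound 2 (0.77 log units; beyond the scatter). Compound 3 `CCCCNc1nc(N)nc(C)c1CCCN1CCN(C(=O)OC(C)(C)C)CC1` is compound 1 with tert-butoxycarbonyl in place of methyl on an amine nitrogen in a ring. Among the compounds with values here, no measured step covers this change: the step to compound 2 exchanged the whole ring, whereas here the ring stays and only its substituent changes. A modest rise, smaller than that step, is therefore expected, so a 3.1-fold higher number from compound 1 to compound 3 (0.49 log units; beyond the scatter) is the estimate, with compound 3 expected at 550 nM, likely between 150 nM and 2000 nM.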

Compound 3, half-maximal effective concentration: 300 nM
For compound 3 the middle estimate is 1.8-fold (0.26 log units) above the measured one; measured number inside the range.
By their numbers in this assay, from the lowest: compounds 1 and 3 (each within the scatter of the next); then compound 2.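

Putting the larger tert-butoxycarbonyl, with seven heavy atoms against one, in place of methyl on this ring nitrogen gives a 1.7-fold higher number from compound 1 to compound 3 (0.22 log units; within the scatter) in this assay. At this position, then, a far bulkier substituent leaves the number within the scatter, unlike the exchange of the whole ring in a 5.9-fold higher number from compound 1 to compound 2 (0.77 log units; beyond the scatter). Nothing measured here gives a reason for this. As far as these compounds go, it remains open whether a plain hydrogen, an acetyl group or a benzyl group on that nitrogen would also stay this close to compound 1. From the compounds shown here alone, whether a ring other than piperazine could do the same is also open.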